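Dropping One Methoxy Group: Expected Effect on Cell Growth

The source may hold more compounds than are shown below. What is called first, only, known or untested is meant among the compounds shown, and "the series" means these compounds.

Compound 1 `COc1cc(/C(Cl)=C/C=C(\C#N)C(=O)c2c[nH]c3ccccc23)cc(OC)c1OC`: 35900 nM
Compound 2 `COc1ccc(/C(Cl)=C/C=C(\C#N)C(=O)c2c[nH]c3ccc(Br)cc23)cc1`: "not determined" (no result reported)
Compound 3 `COc1cc(/C(Cl)=C/C=C(\C#N)C(=O)c2c[nH]c3ccc(Br)cc23)cc(OC)c1OC`: 22100 nM

Three compounds share one core and were examined in an ADME assay on Vero cells (Chlorocebus sabaeus) for cytotoxicity, read by sulforhodamine B assay, with a stated time of 48 h; on this read-out lower numbers stand for stronger inhibition of growth and higher numbers for weaker inhibition of growth. Compound 1 gives 35900 nM in this assay, and compound 3 gives 22100 nM. Compound 2 carries one methoxy group where compound 3 carries three, but in this assay the entry for compound 2 reads "not determined" (no result reported). Going by the values given here, the only measured step, a 1.6-fold lower number from compound 1 to compound 3 (0.21 log units; within the scatter), is a bromine added to the bicyclic part of the core; it stays within the scatter. Compound 3 therefore has the lowest of the two numbers, but its gap to compound 1 is within the scatter, so the two cannot be ranked.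

Compound 4 `COc1ccc(/C(Cl)=C/C=C(\C#N)C(=O)c2c[nH]c3ccc(Br)cc23)cc1OC` differs from compound 3 by hydrogen in place of methoxy on an aromatic carbon. Among the compounds with values here, no measured step touches this part of the molecule, and compound 2, the one comparison point with fewer methoxy groups, has no number. Within the data shown here, the only step seen, from compound 1 to compound 3, was within the scatter, which suggests the core tolerates small changes without a clear shift. With nothing pointing either way, compound 4 is expected to show a 1.0-fold lower number from compound 3 to compound 4 (0.00 log units; within the scatter), no step beyond the scatter. In this assay compound 4 is estimated at 22000 nM, with a range from 9000 nM to 50000 nM.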

Compound 4, concentration for total growth inhibition: 38400 nM
The estimate for compound 4 lay 1.7-fold (0.24 log units) below the measured number, within the range that was stated.
By their numbers in this assay, from the lowest: compounds 3, 1 and 4 (each within the scatter of the next).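

Replacing the methoxy group with hydrogen, at the place ortho to a methoxy group and meta to a large group, gives a 1.7-fold higher number from compound 3 to compound 4 (0.24 log units; within the scatter) in this assay and so does not separate the two compounds. Going by these compounds alone, this is the first measured step on the methoxy-bearing ring, as the earlier step changed only the bromo position on the other side of the shared core, and it shows that losing this one methoxy group brings no change beyond the scatter on this read-out. No measured property of these compounds bears on this result, so nothing here accounts for it.

From the compounds shown here alone, the steps that lead to compound 2, which has one methoxy group fewer than compound 4, cannot be read, so it remains open whether removing a second methoxy group would matter when the first did not. Going by these compounds, it also remains open whether a different group at this place, such as an amine, a carboxylic acid or a longer chain, would move the number beyond the scatter.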